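The source may hold more compounds than are shown below. What is called first, only, known or untested is meant among the compounds shown, and "the series" means these compounds.

Measured so far, in a functional assay on MDA-MB-231 cells (Homo sapiens) for cytotoxicity, read by MTT assay, with a stated time of 72 h, tested at 5 uM, in the absence of a further agent; on this read-out higher numbers stand for a weaker effect at the one concentration tested and lower numbers for a stronger effect:
compound 1 `CC1(C)CC(N)=Nc2ccc(Cl)cc21` gives 81%
compound 2 `CNC1=Nc2ccc(Cl)cc2C(C)(C)C1` gives 92.3%
compound 3 `CCCNC1=Nc2ccc(Cl)cc2C(C)(C)C1` gives 82.4%

Compound 2 holds the largest of the three numbers, meaning the weakest effect at this concentration. Its lead over compound 1 is real, as the step of a number 11.3 percentage points higher from compound 1 to compound 2 (beyond the scatter) is beyond the scatter; against compound 3 the step of a number 9.9 percentage points lower from compound 2 to compound 3 (within the scatter) stays within the scatter, so those two cannot be told apart.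

Compound 4 `CN(C)CCNC1=Nc2ccc(Cl)cc2C(C)(C)C1` differs from compound 2 by (dimethylamino)methyl in place of hydrogen on a saturated chain carbon bound to an amine nitrogen. Among the measured compounds shown here, the only measured step at that same place is a number 9.9 percentage points lower from compound 2 to compound 3 (within the scatter), a small change that did not exceed the scatter. On that basis a similar outcome is expected: a step of a number 5.3 percentage points lower from compound 2 to compound 4 (within the scatter), with compound 4 estimated at 87%, between 70% and 100%.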

Compound 4, a percentage reported as activity, at one concentration (the size of the read-out at that concentration, not a potency): 50.8%
The estimate for compound 4 lay 36.2 percentage points above the measured number; measured number below the stated range.
By their numbers in this assay, from the lowest: compound 4; then compounds 1, 3 and 2 (each within the scatter of the next, the first and the last beyond it).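

The earlier groups on the amine nitrogen gave at most modest shifts, whereas in this assay this position responds strongly to 2-(dimethylamino)ethyl, with a number 30.2 percentage points lower from compound 1 to compound 4 (beyond the scatter) and a number 41.5 percentage points lower from compound 2 to compound 4 (beyond the scatter). The closest comparison exchanges only the end of the chain, methyl for dimethylamino, and still gives a number 31.6 percentage points lower from compound 3 to compound 4 (beyond the scatter), so the stronger effect goes with the dimethylamino end, not with chain length alone. Nothing available here explains this effect. The compounds shown leave open how a primary amine, a morpholine ring or a longer 3-(dimethylamino)propyl chain at this place would compare.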